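This account rests on a few compounds, and the source may have more. Where it says the series, first, only, none or still open, it means among the compounds named here.

- Compound 1 `CCCCCCCCCCCOC1=C(O)OC(C(O)CO)C1=O`: 13000 nM
- Compound 2 `CCCCCCCCCCCCCCOC1=C(O)OC(C(O)CO)C1=O`: 7400 nM
- Compound 3 `CCCCCCCCCCCCCCCOC1=C(O)OC(C(O)CO)C1=O`: 5600 nM

These numbers come from a functional assay (brain) for inhibition, with Rattus norvegicus as the target; a higher number here means a weaker inhibitor, a lower number a stronger inhibitor. Compound 3 stands with compound 2 at the low end of this short series. The closest comparison shows a 1.3-fold lower number from compound 2 to compound 3 (0.12 log units; within the scatter), whereas the widest shows a 2.3-fold lower number from compound 1 to compound 3 (0.37 log units; beyond the scatter). Compound 4 `CCCCCCCCCCCCCCCCCCCCCOC1=C(O)OC(C(O)CO)C1=O` is unmeasured and differs by hexyl in place of hydrogen on a saturated chain carbon, ten or more bonds along the chain from an oxygen on an unsaturated carbon, a longer addition than any so far. The steps above, together with a 1.8-fold lower number from compound 1 to compound 2 (0.24 log units; within the scatter), all run downward as the chain grows, so a further modest fall in this assay is expected, although nothing yet shows that the trend holds this far. The expected change is a 2.2-fold lower number from compound 3 to compound 4 (0.35 log units; beyond the scatter). For compound 4 the estimate is 2500 nM, with an expected range of 800 nM to 7500 nM.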

Compound 4, half-maximal inhibitory concentration: 11000 nM
For compound 4 the middle estimate is 4.4-fold (0.64 log units) below the measured one; measured number outside the range, above it.
By their numbers in this assay, from the lowest: compounds 3, 2, 4 and 1 (each within the scatter of the next, the first and the last beyond it).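

Adding hexyl on this saturated chain carbon does not extend the earlier downward run: the steps (a 2.0-fold higher number from compound 3 to compound 4 (0.29 log units; within the scatter)), (a 1.5-fold higher number from compound 2 to compound 4 (0.17 log units; within the scatter)) and (a 1.2-fold lower number from compound 1 to compound 4 (0.07 log units; within the scatter)) all lie within the scatter. Compound 4 therefore cannot be told apart from any of the three shorter-chain compounds, even though compound 1 and compound 3 can be told apart from each other. No supporting evidence accounts for this result.

Still open, from the compounds shown here alone, is how chains of intermediate length, or a longer chain than that of compound 4, would behave. A chain ending in a carboxylic acid or an amine also remains untested among the compounds shown.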